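Reversing the sulfonamide linkage on a naphthol biaryl

A few compounds are considered here, and "the series" means these few. Any claim that something is new, unique, unknown or untested is made for them only; others in the source may bear on it.

Measured so far:
compound 1, `COc1ccc(-c2ccc3c(O)cccc3c2)cc1`, 20%
compound 2, `CNS(=O)(=O)c1ccc(-c2ccc3c(O)cccc3c2)cc1`, 57%

In an assay for binding affinity to 17-beta-hydroxysteroid dehydrogenase type 2 (Homo sapiens), with a stated time of 20 min, tested at 1 uM (a higher number here means more inhibition at the concentration tested (going by the name of the read-out), a lower number less inhibition), compound 2 gives 57%, the highest of the two numbers; its nearest neighbour is compound 1 with 20%. Going by the values given here, the one measured step, a number 37 percentage points higher from compound 1 to compound 2 (beyond the scatter), shows that a sulfonamide-type group on this ring lifts the read-out well beyond the scatter compared with methoxy.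

Compound 3, `CS(=O)(=O)Nc1ccc(-c2ccc3c(O)cccc3c2)cc1`, differs from compound 2 as follows: methanesulfonamido in place of methylsulfamoyl on an aromatic carbon. The group keeps the same atoms at the same place on the ring, para to a large group, but joined differently. Among the compounds with values here, no measured step covers such a swap, so the step from compound 1 to compound 2 bears on it only by showing that a sulfonamide-bearing ring scores higher than a methoxy-bearing one. A small decrease, within the scatter, is therefore expected: a number 12 percentage points lower from compound 2 to compound 3 (beyond the scatter). Compound 3 is estimated at 45%, with a range from 20% to 70%.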

Compound 3, a percentage reported as inhibition, at one concentration (the size of the read-out at that concentration, not a potency): 75%
For compound 3 the middle estimate is 30 percentage points below the measured one; the measured number lies above the stated range.
By their numbers in this assay, from the lowest: compound 1; then compound 2; then compound 3.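

Sulfonamide-type groups at this place on the ring are therefore not interchangeable: in this assay, the same atoms joined differently, para to a large group, give a number 18 percentage points higher from compound 2 to compound 3 (beyond the scatter). Against the methoxy group, methanesulfonamido gives a number 55 percentage points higher from compound 1 to compound 3 (beyond the scatter), a larger gain than methylsulfamoyl showed, so the direction of the sulfonamide linkage matters as well as its presence. Nothing available explains why this reversed linkage scores higher.

From the compounds shown here alone, whether the gain needs the sulfonyl group at all remains open, as an acetamido group at the same place would test, and so does whether the methyl can be replaced by a longer chain such as ethyl or propyl. These percentages also come from a single concentration, so they leave the potency of compound 3 open.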